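Cyclopropyl to Cyclopentyl on the Amino Side Chain

This account rests on a few compounds, and the source may have more. Where it says the series, first, only, none or still open, it means among the compounds named here.

Three compounds measured in a functional assay on MV4-11 cells (Homo sapiens) for antiproliferative activity, read by CellTiter-Glo, with a stated time of 72 h (on this read-out higher numbers stand for weaker inhibition of growth and lower numbers for stronger inhibition of growth), give these values:

- Compound 1 `COCCN[C@H]1CC[C@H](Nc2cc(-c3csc(SCC4CCOCC4)n3)c(Cl)cn2)CC1` gives 340 nM in this test
- Compound 2 `CNc1nc(-c2cc(N[C@H]3CC[C@H](NCCOC)CC3)ncc2Cl)cs1` gives 530 nM in this test
- Compound 3 `COCCN[C@H]1CC[C@H](Nc2cc(-c3csc(NCC4CC4)n3)c(Cl)cn2)CC1` gives 740 nM in this test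

Compound 3 at 740 nM lies within the scatter of compound 2 and inhibits growth less strongly than compound 1, as this step shows (a 2.2-fold higher number from compound 1 to compound 3 (0.34 log units; beyond the scatter)). Compound 4 `COCCN[C@H]1CC[C@H](Nc2cc(-c3csc(NCC4CCCC4)n3)c(Cl)cn2)CC1` has cyclopentyl in place of cyclopropyl on a saturated chain carbon bound to a nitrogen on an aromatic ring. The closest evidence is the exchange of hydrogen for cyclopropyl at that same place, which stayed within the scatter (a 1.4-fold higher number from compound 2 to compound 3 (0.14 log units; within the scatter)). Replacing the ((oxan-4-yl)methyl)sulfanyl group gave steps no larger than modest (a 1.6-fold higher number from compound 1 to compound 2 (0.19 log units; within the scatter)) and (a 2.2-fold higher number from compound 1 to compound 3 (0.34 log units; beyond the scatter)). Among the compounds with values here, no measured compound carries cyclopentyl, so this evidence is indirect. No step beyond the scatter is therefore expected in this assay for this change. The estimated step is small (a 1.2-fold lower number from compound 3 to compound 4 (0.09 log units; within the scatter)). The estimate for compound 4 is 600 nM with an expected range of 250 nM to 1400 nM on this read-out.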

Compound 4, concentration for 50% growth inhibition: 2160 nM
Estimate against measurement, compound 4: 3.6-fold (0.56 log units) below, outside the stated range (above it).
By their numbers in this assay, from the lowest: compounds 1, 2 and 3 (each within the scatter of the next, the first and the last beyond it); then compound 4.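

Up to this point, swapping groups at this place had moved the number only a little in this assay, but the larger ring brings a clear loss of growth inhibition (a 2.9-fold higher number from compound 3 to compound 4 (0.47 log units; beyond the scatter)). Cyclopentyl on the saturated chain carbon is therefore not interchangeable with cyclopropyl or hydrogen: the methylamino compound also stands clearly ahead (a 4.1-fold higher number from compound 2 to compound 4 (0.61 log units; beyond the scatter)), and the gap to the ((oxan-4-yl)methyl)sulfanyl compound is the widest in the set (a 6.4-fold higher number from compound 1 to compound 4 (0.80 log units; beyond the scatter)). No accompanying measurement offers a reason for this loss.

The compounds shown leave open whether cyclobutyl, the ring size in between, would behave like cyclopropyl or like cyclopentyl. They also leave open whether an open chain such as isobutyl, or an oxan-4-yl ring on the same carbon, would restore growth inhibition.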